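From 3-methylphenyl to 4-chlorophenyl on the aromatic nitrogen

This account rests on a few compounds, and the source may have more. Where it says the series, first, only, none or still open, it means among the compounds named here.

In a functional assay on A549 cells (Homo sapiens) for inhibition, read by MTT assay, with a stated time of 72 h (on this read-out higher numbers stand for weaker inhibition and lower numbers for stronger inhibition), compound 1 (`Cc1cc2occ(-c3nc(-c4ccccc4)c(-c4ccccc4)n3-c3ccc([N+](=O)[O-])cc3)c(=O)c2cc1Cl`) gives 3130 nM and compound 2 (`Cc1cccc(-n2c(-c3coc4cc(C)c(Cl)cc4c3=O)nc(-c3ccccc3)c2-c2ccccc2)c1`) gives 12500 nM as the higher of the two numbers. Compound 3 (`Cc1cc2occ(-c3nc(-c4ccccc4)c(-c4ccccc4)n3-c3ccc(Cl)cc3)c(=O)c2cc1Cl`) is unmeasured and carries 4-chlorophenyl in place of 3-methylphenyl on an aromatic nitrogen. Among the compounds with values here, the only measured step at this place is a 4.0-fold higher number from compound 1 to compound 2 (0.60 log units; beyond the scatter) and it was modest, with 3-methylphenyl replacing 4-nitrophenyl. A modest step to a lower number is therefore expected in this assay here. The expected change is a 2.1-fold lower number from compound 2 to compound 3 (0.32 log units; beyond the scatter) in this estimate. Compound 3 is expected at 6000 nM within 2500 nM to 14000 nM once measured.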

Compound 3, half-maximal inhibitory concentration: 12500 nM
For compound 3 the middle estimate is 2.1-fold (0.32 log units) below the measured one; low and high end bracket the measured number.
By their numbers in this assay, from the lowest: compound 1; then compounds 2 and 3 (each within the scatter of the next).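

In this assay the exchange of 3-methylphenyl for 4-chlorophenyl on the aromatic nitrogen gives no change at the digits printed from compound 2 to compound 3 (within the scatter) and so does not separate these two groups at this position. Chloro in place of nitro gives a 4.0-fold higher number from compound 1 to compound 3 (0.60 log units; beyond the scatter) and thus leaves compound 1, with its 4-nitrophenyl, apart from both other compounds. No supporting evidence bears on this result.

Going by these compounds, what a phenyl carrying an amine or a carboxylic acid would give on this aromatic nitrogen stays open. So does whether the lower number of compound 1 belongs to nitro alone.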